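Methoxy on the benzyl ring of an N-chloro quinolinone

The compounds below may be only part of what the source reports. "The series", "measured", "known", "first", "only" and "open" are said of these compounds alone.

Two compounds of the series have numbers in a functional assay on CHO cells for positive allosteric modulation of metabotropic glutamate receptor 2 (Homo sapiens), read by scintillation counting and GTPgammaS binding, with a stated time of 30 min; on this read-out higher numbers stand for an effect only at larger amounts of compound and lower numbers for an effect already at smaller amounts. Compound 1 `CCCn1ccc2c(NCc3cccc(OC)c3)cccc2c1=O` gives 316 nM in this assay. Compound 2 `CCCn1ccc2c(N(Cl)Cc3ccccc3)cccc2c1=O` gives 50100 nM in this assay, the higher of the two numbers, and the gap to compound 1 lies beyond the scatter. The two structures differ in more than one place, so no single step can be read from them.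

Compound 3 `CCCn1ccc2c(N(Cl)Cc3cccc(OC)c3)cccc2c1=O` differs from compound 2 by one change: methoxy in place of hydrogen on an aromatic carbon. Among the measured compounds shown here, no measured pair shows this change on its own. The weak number of compound 2 in this assay, 50100 nM, is taken as the starting point, and a moderate step towards a lower number is expected, though not a return to the range of compound 1. The expected step of a 2.5-fold lower number from compound 2 to compound 3 (0.40 log units; beyond the scatter) is therefore modest. For compound 3 in this assay the estimate is 20000 nM, with a range from 5000 nM to 80000 nM.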

Compound 3, half-maximal effective concentration: 501 nM
Compound 3: the middle estimate sits 40-fold (1.60 log units) above what was measured; measured number below the stated range.
By their numbers in this assay, from the lowest: compounds 1 and 3 (each within the scatter of the next); then compound 2.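

In this assay, putting methoxy in place of hydrogen on the aromatic carbon meta to a large group gives a 100-fold lower number from compound 2 to compound 3 (2.00 log units; beyond the scatter) and so carries most of the difference between the two chlorinated compounds shown. With the 3-methoxyphenyl group in place, chloro in place of hydrogen on the nitrogen gives a 1.6-fold higher number from compound 1 to compound 3 (0.20 log units; within the scatter) and does not separate the two compounds at this read-out, so the weak number of compound 2 cannot be read as a penalty of the chloro alone. No measurement on these compounds accounts for the size of the methoxy step.

On these data alone, whether the methoxy step holds when the nitrogen carries hydrogen instead of chloro stays open. So does whether ethoxy, hydroxyl or fluoro on the same aromatic carbon would give a step of similar size.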